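The source may hold more compounds than are shown below. What is called first, only, known or untested is meant among the compounds shown, and "the series" means these compounds.

Measured so far:
compound 1, `CCc1ccc(C(=O)Nc2cccc(NC(=O)COc3ccc4c(=O)ccoc4c3)c2)cc1`: 24 nM
compound 2, `O=C(COc1ccc2c(=O)ccoc2c1)Nc1cccc(NS(=O)(=O)c2ccc(OC(F)(F)F)cc2)c1`: 1280 nM

In an assay on isolated protein for inhibition of Rho-associated protein kinase 2 (Homo sapiens), read by scintillation counting, radiometric assay and 33P incorporation, with a stated time of 40 min, in the presence of a further agent that is not named here (a lower number here means a stronger inhibitor, a higher number a weaker inhibitor), compound 1 gives 24 nM, the lowest of the two numbers shown. Within the data shown here, compound 2 gives 1280 nM in this assay, a much higher number, beyond the usual scatter; no single-point step between these two is defined, as they differ in more than one place, so only the gap between the two values is noted.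

Compound 3, `O=C(COc1ccc2c(=O)ccoc2c1)Nc1cccc(NC(=O)c2ccc(C(=O)O)cc2)c1`, has not yet been measured in this assay. It differs from compound 1 in one place: carboxy in place of ethyl on an aromatic carbon. The change sits on an aromatic carbon of a six-membered aromatic ring of carbon only, para to a large group. Among the measured compounds shown here, no measured pair isolates this change, so there is nothing to anchor a direction, and the expectation rests on compound 1 alone.

The step from compound 1 to compound 3 in this assay is expected to be modest and toward a higher number, a 6.3-fold higher number from compound 1 to compound 3 (0.80 log units; beyond the scatter), with wide uncertainty either way. Compound 3 is therefore estimated at 150 nM in this assay, within a range of 30 nM to 800 nM.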

Compound 3, half-maximal inhibitory concentration: 2030 nM
For compound 3 the middle estimate is 14-fold (1.13 log units) below the measured one, outside the stated range (above it).
By their numbers in this assay, from the lowest: compound 1; then compounds 2 and 3 (each within the scatter of the next).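

In this assay, among these compounds, carboxy in place of ethyl on an aromatic carbon, para to a large group, gives the first single-place step and a large one (an 85-fold higher number from compound 1 to compound 3 (1.93 log units; beyond the scatter)). The value at this position therefore depends strongly on the group carried there: with the rest of compound 1 unchanged, replacing 4-ethylphenyl with 4-carboxyphenyl is enough to lose most of the inhibition seen for compound 1. No measurement at hand bears on what lies behind this step.

A single change at this position cannot show whether the loss follows from removing ethyl or from introducing carboxy, nor how steeply the value varies with the group placed there. As far as these compounds go, it remains open whether a longer chain, a methoxy group, an amine or the methyl ester of the carboxylic acid at this same aromatic carbon would give a number close to that of compound 1 or one closer to that of compound 3.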